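The compounds below may be only part of what the source reports. "The series", "measured", "known", "first", "only" and "open" are said of these compounds alone.

Measured in a functional assay on MCF7 cells (Homo sapiens) for cytotoxicity, read by ELISA, with a stated time of 4 days (a lower number here means a stronger inhibitor, a higher number a weaker inhibitor), so far:

compound 1, `Clc1ccc(-c2cc(-c3ccoc3)cc(-c3ccc(Cl)s3)n2)cc1`, gives 2600 nM
compound 2, `Clc1ccc(-c2cc(-c3ccoc3)cc(-c3cccnc3)n2)s1`, gives 3480 nM
compound 3, `Cc1ccsc1-c1cc(-c2ccc(Cl)o2)cc(-c2ccc(Cl)cc2)n1`, gives 15300 nM

Compound 1 and compound 2 differ in one place: pyridin-3-yl in place of 4-chlorophenyl on an aromatic carbon. This change produced a 1.3-fold higher number from compound 1 to compound 2 (0.13 log units; within the scatter), so the two numbers are not separated in this assay.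

Compound 3 differs from compound 1 in more than one place; the difference between the two cores is not broken down here. Compound 3 has the highest number of the three, and its gaps to compound 2 and to compound 1 are both beyond the scatter.

Compound 4, `Cc1ccsc1-c1cc(-c2ccc(Cl)o2)cc(-c2cccnc2)n1`, is not yet measured. It carries the same kind of change as the pair above: pyridin-3-yl in place of 4-chlorophenyl on an aromatic carbon. The surroundings of the place are not identical, however: in compound 1 the place is meta to a 5-chlorothiophen-2-yl group and meta to a furan-3-yl group, whereas in compound 3 it is meta to a 3-methylthiophen-2-yl group and meta to a 5-chlorofuran-2-yl group.

The step from compound 3 to compound 4 in this assay is expected to be small, a 1.3-fold higher number from compound 3 to compound 4 (0.12 log units; within the scatter), because the same change earlier gave a 1.3-fold higher number from compound 1 to compound 2 (0.13 log units; within the scatter). The expectation rests on one prior instance only, in a different core, so it is held loosely. Compound 4 is therefore estimated at 20000 nM, with a likely range from 8000 nM to 50000 nM.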

Compound 4, half-maximal inhibitory concentration: 5810 nM
For compound 4 the middle estimate is 3.4-fold (0.54 log units) above the measured one; the measured number lies below the stated range.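

In this assay, putting pyridin-3-yl in place of 4-chlorophenyl gives a 2.6-fold lower number from compound 3 to compound 4 (0.42 log units; beyond the scatter). The change therefore does not carry a fixed size from one core to the other in this series, and the result on one core would not have served as a reliable guide to the result on the other: the same change on two cores in this assay, a 1.3-fold higher number (0.13 log units; within the scatter) from compound 1 to compound 2 and a 2.6-fold lower number (0.42 log units; beyond the scatter) from compound 3 to compound 4, 3.5-fold (0.55 log units) apart, beyond the scatter of two such steps

Going by these compounds alone, this shows that the outcome of the change depends on its surroundings, but it rests on only one pair per core and does not show which difference between the cores matters, whether the 3-methylthiophen-2-yl group, the 5-chlorofuran-2-yl group or both, nor what the change would do on a third core.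

The compounds shown leave open how an amine, a carboxylic acid or a longer alkyl chain would read at this place in this assay, since only 4-chlorophenyl and pyridin-3-yl appear there. Also open, going by these compounds, is whether exchanging the 3-methylthiophen-2-yl and 5-chlorofuran-2-yl groups one at a time would locate the source of the gap between the two steps.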